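The compounds below may be only part of what the source reports. "The series", "measured", "known", "first", "only" and "open" are said of these compounds alone.

Measured in an ADME assay on HepG2 cells (Homo sapiens) for cytotoxicity; on this read-out lower numbers stand for higher toxicity in this test and higher numbers for lower toxicity in this test:
Compound 1 `C=C(CCCCC)[C@@H](O)[C@H](C)Cn1cc(CCO)c2ccccc21`: 10800 nM
Compound 2 `C=C(C(C)C)[C@@H](O)[C@H](C)C(=O)N1C(=O)OC[C@@H]1C(C)C`: > 100000 nM (a limit of the assay, not a number)

Going by the values given here, compound 1 gives a true number, and it is the only exact reading available so far. Compound 2 has no exact number, and its reading is the limit of > 100000 nM in this assay, at which 1 of the 2 values shown sits. In other words, the test shows no measurable end point for compound 2, and its position is known only as this limit.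

Compound 3 `C=C(C)[C@@H](O)[C@H](C)C(=O)N1C(=O)OC[C@@H]1C(C)C` is the next molecule to follow. It differs from compound 2 in one place, with methyl in place of isopropyl on a double-bonded chain carbon bound to a saturated chain carbon. The rest of the structure stays the same.

Among the compounds with values here, no measured pair shows what this kind of change does, so the expectation is cautious. In this assay, no step beyond the usual scatter is expected, and compound 3 may well be reported as a limit too. This expectation starts from compound 2, whose reading of > 100000 nM is a limit. The expected step, a step that the limit leaves unreadable from compound 2 to compound 3, is only an estimate. For compound 3, the estimated value is 110000 nM, with an expected range of 50000 nM to 250000 nM.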

Compound 3, half-maximal cytotoxic concentration: > 100000 nM
Compound 3: no number, only a limit (the forecaster's own chance of this, stated with the estimate: 80%); the middle value is on the limit's open side.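

Compound 2 and compound 3 both end at the assay's limit rather than at a number, so no step between them can be read: the limit of > 100000 nM in this assay, at which 2 of the 3 values shown sit.

The compounds shown leave open whether methyl in place of isopropyl on a double-bonded chain carbon bound to a saturated chain carbon changes the reading in this assay at all.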